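This account rests on a few compounds, and the source may have more. Where it says the series, first, only, none or still open, it means among the compounds named here.

Values measured in an ADME assay on MCF7 cells (Homo sapiens) for cytotoxicity, with a stated time of 72 h; a higher number here means a weaker inhibitor, a lower number a stronger inhibitor:
- compound 1 `COc1cccc(CNc2ncnc3c2ncn3C2CCCCO2)c1` gives 97000 nM as a number
- compound 2 `COc1ccc(CNc2ncnc3c2ncn3C2CCCCO2)c(OC)c1` gives > 25000 nM as a limit
- compound 3 `COc1ccc(CNc2ncnc3c2ncn3C2CCCCO2)cc1OC` gives > 100000 nM as a limit

Compound 3 has no exact number. On these data alone, it stands only at the limit of > 100000 nM in this assay, at which 1 of the 3 values shown sits, so its true value is unknown.

Compound 4 `COc1ccc(CNc2ncnc3c2ncn3C2CCCCO2)c(OC)c1OC` differs from compound 3 by one more group, with methoxy in place of hydrogen on an aromatic carbon. The new group sits ortho to a methoxy group and ortho to a large group.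

One measured step involves the same kind of swap, an at least 1.0-fold higher number from compound 1 to compound 3 (0.01 log units; that floor lies within the scatter). That figure is only a floor, and it lies within the scatter, so it shows no clear change and gives no reason to expect a large shift in either direction. The expected move is therefore none beyond the scatter, as an estimated a number no higher from compound 3 to compound 4 (the limit leaves the size open). The assay may again report only a limit.

For compound 4 the estimated value in this assay is 100000 nM, with an expected range from 35000 nM to 200000 nM.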

Compound 4, half-maximal inhibitory concentration: > 37500 nM
Compound 4: a limit, no number; the forecaster's own chance of this, stated with the estimate: 65%; the middle value does not contradict the limit.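

Compound 4 gives only a limit, as do compound 2 and compound 3, so the steps from compound 2 and from compound 3 to compound 4 cannot be read. The compounds shown leave open what exact numbers these three would reach in this assay, and so what each added methoxy changes.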